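From Isopropyl to Neopentyl on the Amide Carbonyl

The source may report more compounds than this note shows. Statements on the series, on what has been measured and on what is new or still open speak of the compounds shown alone.

Two compounds have been tested in an assay on isolated protein for inhibition of Fatty-acid amide hydrolase 1 (Homo sapiens); on this read-out higher numbers stand for weaker inhibition and lower numbers for stronger inhibition:

compound 1 `O=C(CCCC1CCN(C(=O)C2CCCCC2)CC1)c1ncco1`: 45 nM
compound 2 `CC(C)C(=O)N1CCC(CCCC(=O)c2ncco2)CC1`: 250 nM

Within the data shown here, of these two numbers, compound 2 has the higher one; its nearest neighbour is compound 1, and the only measured step runs from compound 1 to compound 2 a 5.6-fold higher number from compound 1 to compound 2 (0.74 log units; beyond the scatter). The new compound 3 `CC(C)(C)CC(=O)N1CCC(CCCC(=O)c2ncco2)CC1` changes the same place again: neopentyl in place of isopropyl on a carbonyl carbon. Among the measured compounds shown here, the one step that bears on it shows that, on this carbonyl carbon, trading the cyclohexyl group for the isopropyl group weakened inhibition by a modest amount in this assay. Compound 3 now carries the group with more carbon atoms than isopropyl, so a step back toward the number of compound 1 is expected, a 2.8-fold lower number from compound 2 to compound 3 (0.44 log units; beyond the scatter), though the direction rests on a single measured pair. Compound 3 is therefore estimated at 90 nM, with a range from 30 nM to 300 nM.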

Compound 3, half-maximal inhibitory concentration: 90 nM
Compound 3: the middle estimate sits on the measured number at the digits printed; the measured number falls inside the stated range.
By their numbers in this assay, from the lowest: compounds 1 and 3 (each within the scatter of the next); then compound 2.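

In this assay, this place on the carbonyl carbon now has a second step, and it runs opposite to the first (a 2.8-fold lower number from compound 2 to compound 3 (0.44 log units; beyond the scatter)). The weaker inhibition seen with isopropyl therefore does not simply follow from losing the ring, as the open-chain neopentyl group, with 5 carbon atoms against 3 for isopropyl, cannot be told apart from the cyclohexyl group of compound 1 (a 2.0-fold higher number from compound 1 to compound 3 (0.30 log units; within the scatter)). Nothing available here explains why these groups give these numbers.

On these data alone, it remains open whether the count of carbon atoms or the branched shape matters more, and a straight pentyl chain, which also has 5 carbon atoms, would help separate the two. It is also unknown how the number responds to a longer chain, a phenyl ring or an amine in this place.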